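Changing the carbamate group of compound 2

A few compounds are considered here, and "the series" means these few. Any claim that something is new, unique, unknown or untested is made for them only; others in the source may bear on it.

Measured in an in vivo ADME assay on the whole organism (blood) for pharmacokinetics, with Rattus norvegicus as the target (on this read-out higher numbers stand for fast clearance and lower numbers for slow clearance), as follows:
- Compound 1 `Cc1cc(C(=O)NCc2ccccc2)nn1Cc1cc(Cl)ccc1OCc1ccccc1` gives 75 mL/min/kg
- Compound 2 `Cc1cc(NC(=O)OCc2ccccn2)nn1Cc1cc(Cl)ccc1OCc1ccccc1` gives 98 mL/min/kg

Compound 2 sits within the usual scatter of compound 1, so the two cannot be ranked. Compound 3 `Cc1cc(NC(=O)O[C@H]2CCOC2)nn1Cc1cc(Cl)ccc1OCc1ccccc1` carries oxolan-3-yl in place of (pyridin-2-yl)methyl on an oxygen next to a carbonyl group. Among the measured compounds shown here, the one measured step (a 1.3-fold higher number from compound 1 to compound 2 (0.12 log units; within the scatter)) replaced the whole group carrying that oxygen and stayed within the scatter, so no step beyond the scatter is expected in this assay here. For the measured compounds named here, no measured step changes this group alone, which makes the guidance weak. The estimated step (a 1.3-fold lower number from compound 2 to compound 3 (0.12 log units; within the scatter)) is therefore small. For compound 3 the estimated value is 75 mL/min/kg with a range from 40 mL/min/kg to 120 mL/min/kg for now.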

Compound 3, clearance: 86 mL/min/kg
Estimate against measurement, compound 3: 1.1-fold (0.06 log units) below; low and high end bracket the measured number.
By their numbers in this assay, from the lowest: compounds 1, 3 and 2 (each within the scatter of the next).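

Unlike the earlier step, this one changes only the group on an oxygen next to a carbonyl group: in this assay, oxolan-3-yl in place of (pyridin-2-yl)methyl gives a small step (a 1.1-fold lower number from compound 2 to compound 3 (0.06 log units; within the scatter)). The wider change, (((oxolan-3-yl)oxy)carbonyl)amino in place of benzylcarbamoyl on an aromatic carbon, is also small (a 1.1-fold higher number from compound 1 to compound 3 (0.06 log units; within the scatter)). No evidence is available to explain these results.

On these data alone, it remains open whether a longer chain or an amine such as piperidin-4-yl on that oxygen would give a step beyond the scatter. As far as these compounds go, the mirror-image form of oxolan-3-yl also remains open.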